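The source may report more compounds than this note shows. Statements on the series, on what has been measured and on what is new or still open speak of the compounds shown alone.

In a functional assay on DU-145 cells (Homo sapiens) for cytotoxicity, read by CCK-8 assay and cell counting, with a stated time of 72 h (a higher number here means a weaker inhibitor, a lower number a stronger inhibitor), compound 3 `COc1ccc(-c2cc3cc(C)ccc3c(-c3cccc(O)c3)n2)c(C)c1` gives 5510 nM. Among the three compounds measured there, this stands as the second highest of the three numbers. Its closest neighbour is compound 2 `COc1cc(OC)cc(-c2cc3ccccc3c(-c3cccc(O)c3)n2)c1`, which gives 3870 nM, and furthest from it is compound 1 `COc1ccc(-c2cc3ccccc3c(-c3cccc(N)c3)n2)cc1`, which gives 8610 nM; both gaps lie within the usual scatter of such measurements, so no order among the three can be read from them.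

Compound 4 `COc1ccc(-c2cc3cc(C)ccc3c(-c3cccc(N)c3)n2)c(C)c1` has not yet been measured. It differs from compound 3 in one place: amino in place of hydroxy on an aromatic carbon. Going by the values given here, no pair of measured compounds differs only in this one place, so the size of the step cannot be taken from the data. Compound 1 also carries the amino group and shows the highest of the three numbers, but its other parts differ from those of compound 3, and its gap to compound 3 is within the scatter. Compound 4 is therefore expected to move, if at all, toward a somewhat higher number, with the step of a 1.4-fold higher number from compound 3 to compound 4 (0.13 log units; within the scatter) anticipated to stay within or only just beyond the scatter. The estimate for compound 4 in this assay is 7500 nM, in a range from 3000 nM to 19000 nM.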

Compound 4, half-maximal inhibitory concentration: 5060 nM
Beside the measured number, compound 4's estimate is 1.5-fold (0.17 log units) above it; measured number inside the range.
By their numbers in this assay, from the lowest: compounds 2, 4, 3 and 1 (each within the scatter of the next, the first and the last beyond it).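

In this assay, going by these compounds alone, the exchange of 3-hydroxyphenyl for 3-aminophenyl gives the first direct reading of this substitution on an otherwise fixed structure, and the step is small and within the scatter (a 1.1-fold lower number from compound 3 to compound 4 (0.04 log units; within the scatter)). Earlier, the amino group appeared only in compound 1, whose other parts also differ, so its contribution could not be separated from theirs. This pair now shows that, on an aromatic carbon meta to a large group and on the core of compound 3, hydroxy and amino cannot be told apart in this read-out, and no accompanying evidence bears on this result.

Within the data shown here, one pair cannot show whether the exchange remains equally small on the cores of compound 1 and compound 2, where no matched pair is available. The compounds shown also leave open how a carboxylic acid, an amide or a fluorine atom at this position would read, and so whether other groups there would give a number beyond the scatter.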